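A few compounds are considered here, and "the series" means these few. Any claim that something is new, unique, unknown or untested is made for them only; others in the source may bear on it.

Compound 1 `CC#CC(CC(=O)O)c1ccc(Oc2ncc(Br)cn2)cc1` gives 1570 nM in a functional assay on CHO cells for agonist activity at Free fatty acid receptor 1 (Homo sapiens), read by FLIPR and calcium flux; on this read-out higher numbers stand for an effect only at larger amounts of compound and lower numbers for an effect already at smaller amounts.
Compound 2 `CC(CC(=O)O)c1ccc(Oc2ccc(Cl)cc2Cl)cc1` gives 2480 nM in this assay.
Compound 3 `CC#CC(CC(=O)O)c1ccc(Oc2ccc(C#N)cc2Br)cc1` gives 85 nM in this assay.

Of these three, compound 3 stands at the lowest number in this assay, and both gaps to the others lie beyond the usual scatter: compound 1 is the nearer of the two and compound 2 the further. Compound 3 thus acts already at the smallest amount among the measured compounds.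

Compound 4 `CC#CC(CC(=O)O)c1ccc(Oc2ccc(C#N)cc2Cl)cc1` has not yet been measured. It differs from compound 3 in a single place: chloro in place of bromo on an aromatic carbon. The ring, the cyano group and the rest of the molecule remain untouched, so the comparison isolates this one exchange of halogen.

Among the measured compounds shown here, no measured pair in this set shows what this exchange does in this assay, so the expectation rests on the small size of the change alone. A step from compound 3 to compound 4 of about a 1.4-fold higher number from compound 3 to compound 4 (0.15 log units; within the scatter) is expected, which would stay within the usual scatter. Compound 4 is therefore estimated at 120 nM, with a range from 50 nM to 300 nM.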

Compound 4, half-maximal effective concentration: 42 nM
Compound 4: the middle estimate sits 2.9-fold (0.46 log units) above what was measured; the measured number lies below the stated range.
By their numbers in this assay, from the lowest: compound 4; then compound 3; then compounds 1 and 2 (each within the scatter of the next).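

Among the compounds shown here, at this place on the ring, meta to a cyano group, the halogen matters: in this assay chloro in place of bromo gives a 2.0-fold lower number from compound 3 to compound 4 (0.31 log units; beyond the scatter) and this is the first single change in the set that can be read directly. The step is modest but lies beyond the usual scatter, so exchanging one heavy atom for another moves the number even though no ring, charge, hydrogen-bond donor or acceptor enters or leaves. Nothing at hand accounts for this step.

On these data alone, with only bromo and chloro compared here, it remains open how fluoro, a methyl group or a methoxy group would fare at this place. Also open, as far as these compounds go, is whether chloro would give a similar step if an amine stood in place of the cyano group.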